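Working notes: compound 4 against compound 2

The source may report more compounds than this note shows. Statements on the series, on what has been measured and on what is new or still open speak of the compounds shown alone.

Of the compounds shown here, three of this set have been measured in a functional assay on K562 cells (Homo sapiens) for cytotoxicity, read by trypan blue exclusion, with a stated time of 96 h; on this read-out higher numbers stand for weaker inhibition and lower numbers for stronger inhibition. Compound 1 `COc1cc(OC)c(/C=C/S(=O)(=O)Cc2ccc(Cl)cc2N)c(OC)c1` gives 2500 nM, compound 2 `COC(=O)CNc1cc(CS(=O)(=O)/C=C/c2c(OC)cc(OC)cc2OC)ccc1OC` gives 100 nM, and compound 3 `COc1ccc(CS(=O)(=O)/C=C/c2cc(OC)c(OC)c(OC)c2)cc1NCC(=O)O` gives 3000 nM. Compound 2 therefore holds the lowest number of the three, and both gaps lie beyond the scatter: compound 1 sits markedly higher and compound 3 higher still. Going by the values given here, no two measured compounds differ in a single place, so no isolated step can be read off; compound 3 shares a nitrogen substituent that ends in an acid with compound 4 but differs from compound 2 in more than one place, and its weaker value can only be noted, not traced to one change.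

Compound 4 `COc1ccc(C(Nc2cc(CS(=O)(=O)/C=C/c3c(OC)cc(OC)cc3OC)ccc2OC)C(=O)O)cc1` is not yet measured. It differs from compound 2 as follows: carboxy(4-methoxyphenyl)methyl in place of (methoxycarbonyl)methyl on a nitrogen on an aromatic ring. The incoming group is larger and brings one hydrogen-bond donor where the leaving group has none. Among the compounds with values here, with no comparable pair in hand, the expectation for this assay rests on the weight of the change alone: a step from compound 2 to compound 4 of a 6.0-fold higher number from compound 2 to compound 4 (0.78 log units; beyond the scatter) is expected, towards a higher number. Compound 4 is thus estimated at 600 nM, with a range from 150 nM to 3000 nM.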

Compound 4, half-maximal inhibitory concentration: 15 nM
Compound 4: the middle estimate sits 40-fold (1.60 log units) above what was measured; measured number outside the range, below it.
By their numbers in this assay, from the lowest: compound 4; then compound 2; then compounds 1 and 3 (each within the scatter of the next).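

The step of a 6.7-fold lower number from compound 2 to compound 4 (0.82 log units; beyond the scatter) in this assay shows that this nitrogen on an aromatic ring accepts a substantially larger group without any loss on this read-out; the number falls beyond the scatter. The change from (methoxycarbonyl)methyl to carboxy(4-methoxyphenyl)methyl adds a six-membered aromatic ring of carbon and a hydrogen-bond donor in a single step, and the lower number comes with both additions together. No measurement on hand accounts for this step.

The single change joins two features, so the compounds shown do not separate the contribution of the 4-methoxyphenyl ring from that of the carboxylic acid in place of the ester. Going by these compounds alone, a plain phenyl ring in place of the 4-methoxyphenyl, a primary amide in place of the carboxylic acid, or a longer chain between the nitrogen and the aromatic ring would each test one part of the change, and the series so far leaves open how far this position tolerates further growth.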